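The source may hold more compounds than are shown below. What is called first, only, known or untested is meant among the compounds shown, and "the series" means these compounds.

In a functional assay on A-431 cells (Homo sapiens) for inhibition, read by MTT assay, with a stated time of 72 h (on this read-out higher numbers stand for weaker inhibition and lower numbers for stronger inhibition), compound 1 `COc1ccc(-c2nnc(SCCCN3CCN(c4nc5ccccc5o4)CC3)o2)cc1` gives 52700 nM, compound 2 `Clc1ccc(-c2nnc(SCCCN3CCN(c4nc5ccccc5o4)CC3)o2)cc1` gives 89600 nM and compound 3 `Brc1ccc(-c2nnc(SCCCN3CCN(c4nc5ccccc5o4)CC3)o2)cc1` gives 57800 nM. These three share the same core and differ only in the group on the aromatic ring: methoxy, chloro or bromo. Compound 3 cannot be separated from the other two. Both a 1.1-fold higher number from compound 1 to compound 3 (0.04 log units; within the scatter) and a 1.6-fold lower number from compound 2 to compound 3 (0.19 log units; within the scatter) lie within the scatter, as does a 1.7-fold higher number from compound 1 to compound 2 (0.23 log units; within the scatter).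

Compound 4 `O=C(NCc1nnc(SCCCN2CCN(c3nc4ccccc4o3)CC2)o1)c1ccccc1` carries a much larger change, with benzamidomethyl in place of 4-bromophenyl on an aromatic carbon. Among the measured compounds shown here, none of the measured steps removes that aromatic ring from the five-membered ring, so they offer only indirect guidance. For the measured compounds named here, they show that swapping methoxy, chloro and bromo left the numbers within the scatter, but no measurement yet tests the new group. The expectation is therefore no step beyond the scatter, held with real uncertainty, and the estimated change is a 1.1-fold lower number from compound 3 to compound 4 (0.02 log units; within the scatter). For compound 4 the expected value is 55000 nM, with an estimated range from 18000 nM to 150000 nM.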

Compound 4, half-maximal inhibitory concentration: 36900 nM
Compound 4: middle estimate off by 1.5-fold (0.17 log units), on the high side, within the range that was stated.
By their numbers in this assay, from the lowest: compounds 4, 1, 3 and 2 (each within the scatter of the next, the first and the last beyond it).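

In this assay, among the compounds shown here, the position on the five-membered aromatic ring, so far seen only with substituted phenyl groups, also accepts benzamidomethyl, a group with a hydrogen-bond donor and acceptor that 4-bromophenyl lacks. Against two of the earlier compounds this large change cannot be told from scatter, with a 1.6-fold lower number from compound 3 to compound 4 (0.19 log units; within the scatter) and a 1.4-fold lower number from compound 1 to compound 4 (0.15 log units; within the scatter), while against the 4-chlorophenyl compound it gives a modest step that does clear the scatter, a 2.4-fold lower number from compound 2 to compound 4 (0.39 log units; beyond the scatter). Replacing the phenyl group attached directly to this ring therefore does not weaken the read-out in any of these three comparisons, but nothing measured here gives a reason for these numbers.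

As far as these compounds go, it remains open whether the amide or the phenyl ring within benzamidomethyl matters for this result, and how a simpler aminomethyl group or a carboxylic acid would behave at the same position. From the compounds shown here alone, the effect of a methoxy, chloro or bromo group on the phenyl ring of benzamidomethyl is also open.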